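Chloro in place of bromo at two positions of one series

This account rests on a few compounds, and the source may have more. Where it says the series, first, only, none or still open, it means among the compounds named here.

Compound 1 `O=C1Nc2ccc(Br)cc2/C1=N/NC(=S)N1CCN(c2ccccc2)CC1` and compound 2 `O=C1Nc2ccc(Cl)cc2/C1=N/NC(=S)N1CCN(c2ccccc2)CC1` share a core and differ by chloro in place of bromo on an aromatic carbon. In a functional assay on A549 cells (Homo sapiens) for inhibition, read by MTT assay, with a stated time of 72 h (on this read-out lower numbers stand for stronger inhibition and higher numbers for weaker inhibition), compound 1 gives 12300 nM, and compound 2 gives 7340 nM; the step is a 1.7-fold lower number from compound 1 to compound 2 (0.22 log units; within the scatter). Compound 3 `O=C1Nc2cccc(Br)c2/C1=N/NC(=S)N1CCN(c2ccccc2)CC1` carries the same atoms joined differently, and how its core differs from that of compound 1 is not broken down here. In this assay compound 3 gives 54000 nM, the highest of the three numbers. Compound 4 `O=C1Nc2cccc(Cl)c2/C1=N/NC(=S)N1CCN(c2ccccc2)CC1` has not yet been measured; it differs from compound 3 by chloro in place of bromo on an aromatic carbon. The surroundings of the place read "ortho to a fused ring; meta to a fused ring" rather than "meta to a fused ring; para to a fused ring". This is the same kind of change, not the same one. On the strength of a 1.7-fold lower number from compound 1 to compound 2 (0.22 log units; within the scatter), a step of a 1.4-fold lower number from compound 3 to compound 4 (0.13 log units; within the scatter) is expected for compound 4. Compound 4 is therefore estimated at 40000 nM, with a range from 15000 nM to 110000 nM.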

Compound 4, half-maximal inhibitory concentration: 55900 nM
The estimate for compound 4 lay 1.4-fold (0.15 log units) below the measured number; the range from low to high includes it.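

In this assay, the same exchange on the second core gives a 1.0-fold higher number from compound 3 to compound 4 (0.02 log units; within the scatter), and the two steps agree as far as the scatter allows: the same change on two cores in this assay, a 1.7-fold lower number (0.22 log units; within the scatter) from compound 1 to compound 2 and a 1.0-fold higher number (0.02 log units; within the scatter) from compound 3 to compound 4, 1.7-fold (0.24 log units) apart, within the scatter of two such steps. On these two cores, then, chloro in place of bromo on an aromatic carbon carries over, with neither step standing out from the scatter. Among the compounds shown here, this rests on only two pairs in a single assay, so it does not show that the exchange would behave the same way on any further core or in other cells.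

The compounds shown leave open what a different group at these places would do. Whether a methoxy group, an amine or a carboxylic acid on the same aromatic carbon would also give steps that agree between the two cores remains unanswered.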